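The compounds below may be only part of what the source reports. "The series", "measured", "known", "first", "only" and "open" are said of these compounds alone.

Measured compounds in a functional assay on HeLa cells (Homo sapiens) for antiproliferative activity, read by MTT assay, with a stated time of 48 h; on this read-out higher numbers stand for weaker inhibition and lower numbers for stronger inhibition:
Compound 1 `CS(=O)(=O)c1ccc(Nc2ncc(F)c(Nc3nc4ccc(Cl)cc4s3)n2)cc1` gives > 50000 nM, a limit of the assay.
Compound 2 `CS(=O)(=O)c1ccc(Nc2ncc(F)c(Nc3nc4ccc(F)cc4s3)n2)cc1` gives > 50000 nM, also a limit of the assay.

Within the data shown here, compound 1 therefore stands only at a limit in this assay, and the single piece of evidence is the limit of > 50000 nM in this assay, at which 2 of the 2 values shown sit. The step that the two limits leave unreadable from compound 1 to compound 2 cannot be read, with both ends at the limit. Compound 3 `CS(=O)(=O)c1ccc(Nc2nccc(Nc3nc4ccc(Cl)cc4s3)n2)cc1` differs from compound 1 by hydrogen in place of fluoro on an aromatic carbon. Among the measured compounds shown here, no measured step touches this change, and the one step recorded gives no size. Compound 3 is expected to stay at the limit, with an estimated 60000 nM (10000 nM to 300000 nM), the expected step that the limit leaves unreadable from compound 1 to compound 3 lying within the scatter.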

Compound 3, half-maximal inhibitory concentration: 1400 nM
The estimate for compound 3 lay 43-fold (1.63 log units) above the measured number; measured number outside the range, below it.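

Among these compounds, this position is the first place where a change gives a readable number: in this assay, hydrogen in place of fluoro on the aromatic carbon of the six-membered aromatic ring with 2 nitrogen gives an at least 35-fold lower number from compound 1 to compound 3 (1.55 log units; beyond the scatter). The fluoro on this carbon therefore separates a measurable compound from one at the limit, which the chloro-to-fluoro change elsewhere could not show. For compound 1, > 50000 nM is a limit of the assay and not a number, so the step has a floor but no upper end: the limit of > 50000 nM in this assay, at which 2 of the 3 values shown sit.

From the compounds shown here alone, whether a methyl, a methoxy or an amine on this carbon stays near compound 3 remains open. Also open, going by these compounds, is whether the same change holds when fluoro replaces the chloro of compound 3.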